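Methoxy for methyl on the pendant aryl of compound 2

The source may report more compounds than this note shows. Statements on the series, on what has been measured and on what is new or still open speak of the compounds shown alone.

Measured compounds:
compound 1 `O=C(O)CCC(=O)N1N=C(c2c(-c3ccc(Br)cc3)c3ccccc3[nH]c2=O)CC1c1ccc(Cl)cc1` gives 290 nM
compound 2 `Cc1cccc(-c2c(C3=NN(C(=O)CCC(=O)O)C(c4ccc(Cl)cc4)C3)c(=O)[nH]c3ccccc23)c1` gives 1900 nM

In an assay on cells (Oocyte) for negative allosteric modulation of glutamate receptor ionotropic, NMDA 2D (Rattus norvegicus), read by two-electrode voltage clamp (on this read-out lower numbers stand for stronger inhibition and higher numbers for weaker inhibition), compound 2 stands with the highest of the two numbers; its nearest neighbour is compound 1, and the step of a 6.6-fold higher number from compound 1 to compound 2 (0.82 log units; beyond the scatter) lies beyond the scatter. Compound 3 `COc1cccc(-c2c(C3=NN(C(=O)CCC(=O)O)C(c4ccc(Cl)cc4)C3)c(=O)[nH]c3ccccc23)c1` has not been measured. It differs from compound 2 by methoxy in place of methyl on an aromatic carbon, on an aromatic carbon of a six-membered aromatic ring of carbon only. No measured step bears on this exchange: the only step shown, from 4-bromophenyl to 3-methylphenyl, is a different change at a different place. With nothing to draw on, the expected step of no change at the digits printed from compound 2 to compound 3 (within the scatter) in this assay is none beyond the scatter. Compound 3 is therefore estimated at 1900 nM, within a range from 600 nM to 6000 nM.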

Compound 3, half-maximal inhibitory concentration: 4500 nM
Compound 3: middle estimate off by 2.4-fold (0.37 log units), on the low side; low and high end bracket the measured number.
By their numbers in this assay, from the lowest: compound 1; then compound 2; then compound 3.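

In this assay, the exchange of methyl for methoxy, meta to a large group, gives a 2.4-fold higher number from compound 2 to compound 3 (0.37 log units; beyond the scatter), so the number at this place depends on which small group sits there, and compound 2 and compound 3 are not interchangeable. The gap to the 4-bromophenyl compound also widens, with a 16-fold higher number from compound 1 to compound 3 (1.19 log units; beyond the scatter), though that step changes both the group and its place on the ring. No measurement offered here accounts for the rise from methyl to methoxy.

The compounds shown leave open whether the lower number of compound 1 comes from the bromine itself or from where it sits on the ring. They also leave open how an amine or a hydroxyl group, meta to a large group, would read against methyl and methoxy.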